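The source may hold more compounds than are shown below. What is called first, only, known or untested is meant among the compounds shown, and "the series" means these compounds.

Measured so far, in a functional assay on the whole organism for antagonist activity, with Mus musculus as the target; a higher number here means that more compound is needed for the effect, a lower number that less compound is needed:
Compound 1 `COc1cc(N)c(Cl)cc1NC(=O)C1CCN(C2CCCC2)CC1`: in this assay compound 1 gives only a limit, > 10 mg/kg.
Compound 2 `COc1cc(N)c(Cl)cc1NC(=O)C1CCN(CC2CC2)CC1`: in this assay compound 2 likewise gives only a limit, > 10 mg/kg.
Compound 3 `COc1cc(N)c(Cl)cc1NC(=O)C1CCN(Cc2cccc(C)c2)CC1`: in this assay compound 3 gives 2.4 mg/kg.

Compound 1 therefore stands at the limit of > 10 mg/kg in this assay, at which 2 of the 3 values shown sit, so no number of its own is known for it. Compound 4 `COc1cc(N)c(Cl)cc1NC(=O)C1CCN(Cc2ccccc2Cl)CC1` differs from compound 1 by 2-chlorobenzyl in place of cyclopentyl on an amine nitrogen in a ring. Among the compounds with values here, two measured steps bear on this change, both replacing a saturated ring on the same nitrogen with a substituted benzyl: an at least 4.1-fold lower number from compound 1 to compound 3 (0.61 log units; beyond the scatter) and an at least 4.1-fold lower number from compound 2 to compound 3 (0.61 log units; beyond the scatter). The step that the two limits leave unreadable from compound 1 to compound 2 gives no usable size. On that basis a step of at least modest size toward a lower number is expected for the change to compound 4, since a benzyl group is the feature shared with compound 3 and its value 2.4 mg/kg. Compound 4 is estimated at 3 mg/kg, with a range from 1 mg/kg to 10 mg/kg. That estimate for compound 4 means an expected step of an at least 3.3-fold lower number from compound 1 to compound 4 (0.52 log units; beyond the scatter).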

Compound 4, dose for half-maximal effect: > 4 mg/kg
Compound 4 ended at the assay's limit; the forecaster's own chance of this, stated with the estimate: 25%; middle value at least 1.3-fold (0.12 log units) from the limit.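

With 2-chlorobenzyl on the amine nitrogen in a ring, compound 4 joins compound 1 and compound 2 in giving only a limit in this assay, though at a different level: the limit of > 4 mg/kg in this assay, at which 1 of the 4 values shown sits.

The one readable step is an at least 1.6-fold higher number from compound 3 to compound 4 (0.22 log units; that floor lies within the scatter), so 2-chlorobenzyl and 3-methylbenzyl are not shown to differ, and compound 3 remains the only compound here with a number of its own. The steps to compound 4 from compound 1 and from compound 2 cannot be read, so the gain seen on going to 3-methylbenzyl is not shown to carry over to 2-chlorobenzyl.

Still open, as far as these compounds go, is how far compound 4 actually lies from compound 3. From the compounds shown here alone, it is also open how an unsubstituted benzyl group on the same nitrogen would compare, which bears on whether the chlorine or the methyl on the benzyl ring matters at all.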